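Bromine to Chlorine at the Cytotoxicity Limit

The source may report more compounds than this note shows. Statements on the series, on what has been measured and on what is new or still open speak of the compounds shown alone.

Of the compounds shown here, three that share one core have been tested in an ADME assay on HepG2 cells (Homo sapiens) for cytotoxicity, read by CellTiter-Glo and resazurin assay, with a stated time of 72 h; on this read-out lower numbers stand for an effect already at smaller amounts and higher numbers for an effect only at larger amounts of compound. Compound 1 `CCOC(=O)CCCCCOc1cccc(CN(C(=O)c2ccc(-c3cccnc3)cc2)C(C)C)c1` carries a pyridin-3-yl on its outer ring. In this assay compound 1 gives > 26000 nM, which is a limit of the measurement and not a number. Compound 2 `CCOC(=O)CCCCCOc1cccc(CN(C(=O)c2ccc(-c3ccc4cc[nH]c4c3)cc2)C(C)C)c1` carries 1H-indol-6-yl in that place. In this assay compound 2 gives > 26000 nM, again a limit. Compound 3 `CCOC(=O)CCCCCOc1cccc(CN(C(=O)c2ccc(-c3cccc(Br)c3)cc2)C(C)C)c1` carries 3-bromophenyl. In this assay compound 3 gives > 26000 nM, also a limit. Because all three values sit at the limit of > 26000 nM in this assay, at which 3 of the 3 values shown sit, the steps between them cannot be read: a step that the two limits leave unreadable from compound 1 to compound 2, a step that the two limits leave unreadable from compound 1 to compound 3 and a step that the two limits leave unreadable from compound 2 to compound 3. Compound 3 therefore stands at the limit together with the other two, and no ordering among the three can be drawn.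

Compound 4 `CCOC(=O)CCCCCOc1cccc(CN(C(=O)c2ccc(-c3cccc(Cl)c3)cc2)C(C)C)c1` differs from compound 3 in one place: chloro in place of bromo on an aromatic carbon. Going by the values given here, no measured step bears directly on this change. Among the compounds with values here, all three measured compounds reach the limit, and that is the only guidance available. The expected step from compound 3 to compound 4 in this assay is therefore a step that the limit leaves unreadable from compound 3 to compound 4, with no direction beyond the scatter. Compound 4 is expected to give 40000 nM, between 20000 nM and 100000 nM, most likely reported as a limit once more.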

Compound 4, half-maximal effective concentration: > 18400 nM
Compound 4: no number, only a limit; the forecaster's own chance of this, stated with the estimate: 85%; the middle value does not contradict the limit.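

Compound 4, like compound 1, compound 2 and compound 3, gives only a limit and not a number in this assay, and none of the steps among these four compounds can be read. The compounds shown leave open at what concentration any of them would reach a half-maximal effect, and whether chloro and bromo differ here at all.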